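The source may report more compounds than this note shows. Statements on the series, on what has been measured and on what is new or still open speak of the compounds shown alone.

In an assay on 32D cells for inhibition of interleukin-15 (Mus musculus), read by resazurin assay, with stated times of 30 min and 2.5 days, in the presence of a further agent that is not named here (on this read-out lower numbers stand for stronger inhibition and higher numbers for weaker inhibition), compound 3 `CN(C)CCCn1nc(Cc2nnc(SCCCCCCCC(=O)Nc3ccc(Cl)cc3Cl)n2C)c2ccccc2c1=O` gives 3200 nM. Compound 2 `Cn1c(Cc2nn(CCC=O)c(=O)c3ccccc23)nnc1SCC(=O)Nc1ccc(Cl)cc1Cl` gives 30000 nM in this assay. Compound 1 `Cn1nc(Cc2nnc(SCCCCCCCC(=O)Nc3ccc(Cl)cc3Cl)n2CCCO[Si](C)(C)C(C)(C)C)c2ccccc2c1=O` reaches only a limit of this assay, > 30000 nM, and the limit of > 30000 nM in this assay, at which 1 of the 3 values shown sits, records this. Among the two compounds that return a number, compound 3 holds the lower one, and its gap to compound 2 lies beyond the usual scatter.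

Compound 4 `Cn1c(Cc2nn(CCC(=O)O)c(=O)c3ccccc23)nnc1SCCCCCCCC(=O)Nc1ccc(Cl)cc1Cl` differs from compound 3 by carboxy in place of (dimethylamino)methyl on a saturated chain carbon, two bonds along the chain from an aromatic nitrogen. Within the data shown here, no measured pair shows this change, so no measured step can be pointed to. The expectation is a move to a higher number in this assay, beyond the scatter, as a 3.8-fold higher number from compound 3 to compound 4 (0.57 log units; beyond the scatter). For compound 4 the estimate in this assay is 12000 nM, expected to fall between 3000 nM and 30000 nM.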

Compound 4, half-maximal inhibitory concentration: > 30000 nM
Compound 4: a limit, no number (the forecaster's own chance of this, stated with the estimate: 35%); middle value at least 2.5-fold (0.39 log units) from the limit.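

In this assay, the change at this position, on a saturated chain carbon two bonds along the chain from an aromatic nitrogen, gives the first readable step there: an at least 9.3-fold higher number from compound 3 to compound 4 (0.97 log units; beyond the scatter). So the end of this chain is not indifferent to the swap of (dimethylamino)methyl for carboxy. Compound 4 gives a limit and not a number, so the step has no upper size: the limit of > 30000 nM in this assay, at which 2 of the 4 values shown sit.

The compounds shown leave open how a primary amine or a methyl ester would read at this position. They also leave open whether a longer chain ending in dimethylamino would give a lower number than compound 3.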